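The source may report more compounds than this note shows. Statements on the series, on what has been measured and on what is new or still open speak of the compounds shown alone.

The measured compounds, with their results in a functional assay on A549 cells (Homo sapiens) for antiproliferative activity, read by MTT assay, with a stated time of 48 h, in the presence of a further agent that is not named here; a lower number here means a stronger inhibitor of growth, a higher number a weaker inhibitor of growth: compound 1 `COc1ccc(-c2nn(-c3ccccc3)cc2C(=O)NOCc2ccc(Cl)cc2Cl)cc1` gives 3830 nM; compound 2 `O=C(NOCc1ccccc1Cl)c1cn(-c2ccccc2)nc1-c1ccc(Cl)cc1` gives 15500 nM; compound 3 `O=C(NOCc1ccc(Cl)cc1Cl)c1cn(-c2ccccc2)nc1-c1ccc(Cl)cc1` gives 13100 nM.

Compound 3 stands near the weak end of these three: its number and that of compound 2 lie within the scatter of each other, while compound 1 sits clearly lower. Compound 4 `O=C(NOCc1ccc(Cl)cc1Cl)c1cn(-c2ccccc2)nc1-c1ccc(F)cc1` differs from compound 3 in one place: fluoro in place of chloro on an aromatic carbon. For the measured compounds named here, two measured steps concern this same ring position. Putting chloro in place of hydrogen there gave a 1.2-fold lower number from compound 2 to compound 3 (0.07 log units; within the scatter), within the scatter, whereas chloro in place of methoxy gave a 3.4-fold higher number from compound 1 to compound 3 (0.53 log units; beyond the scatter). The nearer of these, a halogen joining or leaving, barely moved the number, so no shift beyond the scatter is expected, a 1.0-fold lower number from compound 3 to compound 4 (0.00 log units; within the scatter). Compound 4 is therefore estimated at 13000 nM, between 6000 nM and 30000 nM.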

Compound 4, concentration for 50% growth inhibition: 14000 nM
Compound 4: middle estimate off by 1.1-fold (0.03 log units), on the low side; the measured number falls inside the stated range.
By their numbers in this assay, from the lowest: compound 1; then compounds 3, 4 and 2 (each within the scatter of the next).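

Fluoro in place of chloro gives a 1.1-fold higher number from compound 3 to compound 4 (0.03 log units; within the scatter) and so these two halogens cannot be told apart at this ring position. Fluoro in place of methoxy gives a 3.7-fold higher number from compound 1 to compound 4 (0.56 log units; beyond the scatter) and so the gap seen with chloro also appears with a second halogen, setting the methoxy of compound 1 apart from both. No measurement shown explains this gap. From the compounds shown here alone, whether an amine or a carboxylic acid here would stay with the halogens or come closer to compound 1 remains open. So does whether methoxy keeps its lead with other groups on the rest of the molecule.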